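The compounds below may be only part of what the source reports. "The series", "measured", "known", "first", "only" and "open" are said of these compounds alone.

In a functional assay on A549 cells (Homo sapiens) for antiproliferative activity, read by MTT assay, with a stated time of 48 h (a higher number here means a weaker inhibitor, a lower number a stronger inhibitor), compound 1 `CCn1c(N)c(-c2nc3ccccc3[nH]2)c2nc(C#N)c(C#N)nc21` gives > 50000 nM, which is a limit of the assay. Compound 2 `CCCn1c(N)c(-c2nc3ccccc3[nH]2)c2nc(C#N)c(C#N)nc21` gives 1970 nM, and compound 3 `CN(C)CCCn1c(N)c(-c2nc3ccccc3[nH]2)c2nc(C#N)c(C#N)nc21` gives 10400 nM, the higher of the two actual numbers. Compound 4 `CCN(CC)CCCCn1c(N)c(-c2nc3ccccc3[nH]2)c2nc(C#N)c(C#N)nc21` differs from compound 3 by (diethylamino)methyl in place of dimethylamino on a saturated chain carbon, three bonds along the chain from an aromatic nitrogen, which also reads as 3-(dimethylamino)propyl to 4-(diethylamino)butyl. Among the compounds with values here, three measured steps bear on this only indirectly. Methyl on the chain gave an at least 25-fold lower number from compound 1 to compound 2 (1.40 log units; beyond the scatter), (dimethylamino)methyl gave an at least 4.8-fold lower number from compound 1 to compound 3 (0.68 log units; beyond the scatter), and dimethylamino on the longer chain gave a 5.3-fold higher number from compound 2 to compound 3 (0.72 log units; beyond the scatter). Within the data shown here, no measured step exchanges one amine for the other. Weighing the large gain against the modest loss, a modest lowering is expected in this assay, with a 2.3-fold lower number from compound 3 to compound 4 (0.36 log units; beyond the scatter) as the estimated step. Compound 4 is estimated at 4500 nM, with an expected range of 1200 nM to 18000 nM.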

Compound 4, half-maximal inhibitory concentration: 5750 nM
Estimate against measurement, compound 4: 1.3-fold (0.11 log units) below, and the stated range covers the measured number.
By their numbers in this assay, from the lowest: compound 2; then compounds 4 and 3 (each within the scatter of the next). At a limit, above all of these: compound 1.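

The change from 3-(dimethylamino)propyl to 4-(diethylamino)butyl gives a 1.8-fold lower number from compound 3 to compound 4 (0.26 log units; within the scatter), so this longer amine chain is not told apart from the shorter one. The plain chain of compound 2 keeps its lead over this second amine chain too, with a 2.9-fold higher number from compound 2 to compound 4 (0.47 log units; beyond the scatter). Compound 1 stands at a limit, so an at least 8.6-fold lower number from compound 1 to compound 4 (0.93 log units; beyond the scatter) is only a bound: the limit of > 50000 nM in this assay, at which 1 of the 4 values shown sits.

An unsubstituted butyl chain would separate chain length from the amine, since both change together in compound 4. As far as these compounds go, a morpholine or a hydroxyl at the chain end remains open.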